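Adding a nitro group to the furan ester of a triterpenoid

This account rests on a few compounds, and the source may have more. Where it says the series, first, only, none or still open, it means among the compounds named here.

Compound 1 `CC1=CC[C@H]2[C@H](CC[C@]2(C)O)C(C)(C)[C@@H]1CC[C@H]1[C@]2(C)CC[C@H](OC(=O)c3ccccc3)C(C)(C)O[C@H]2CC[C@@]1(C)O` carries a benzoate ester on a shared core; in a functional assay on MCF7 cells (Homo sapiens) for antiproliferative activity, read by MTT assay, with a stated time of 72 h (on this read-out higher numbers stand for weaker inhibition and lower numbers for stronger inhibition), compound 1 gives 21000 nM. Compound 2 `CC1=CC[C@H]2[C@H](CC[C@]2(C)O)C(C)(C)[C@@H]1CC[C@H]1[C@]2(C)CC[C@H](OC(=O)c3ccc([N+](=O)[O-])cc3)C(C)(C)O[C@H]2CC[C@@]1(C)O` differs from compound 1 by nitro in place of hydrogen on an aromatic carbon, and in this assay compound 2 gives 21600 nM, so the step is a 1.0-fold higher number from compound 1 to compound 2 (0.01 log units; within the scatter). Compound 3 `CC1=CC[C@H]2[C@H](CC[C@]2(C)O)C(C)(C)[C@@H]1CC[C@H]1[C@]2(C)CC[C@H](OC(=O)c3ccco3)C(C)(C)O[C@H]2CC[C@@]1(C)O` differs from compound 1 by furan-2-yl in place of phenyl on a carbonyl carbon; in this assay compound 3 gives 25700 nM. Compound 4 `CC1=CC[C@H]2[C@H](CC[C@]2(C)O)C(C)(C)[C@@H]1CC[C@H]1[C@]2(C)CC[C@H](OC(=O)c3ccc([N+](=O)[O-])o3)C(C)(C)O[C@H]2CC[C@@]1(C)O` is not yet measured and differs from compound 3 by nitro in place of hydrogen on an aromatic carbon. This is the same kind of change as from compound 1 to compound 2, though here the nitro group sits on a five-membered aromatic ring with one oxygen, next to the ring oxygen, rather than on a six-membered ring of carbon only, para to a large group. Because a 1.0-fold higher number from compound 1 to compound 2 (0.01 log units; within the scatter) stayed within the scatter, the expected step for compound 4 is a 1.0-fold higher number from compound 3 to compound 4 (0.01 log units; within the scatter), with compound 4 estimated at 26000 nM.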

Compound 4, half-maximal inhibitory concentration: 21300 nM
For compound 4 the middle estimate is 1.2-fold (0.09 log units) above the measured one, within the range that was stated.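

In this assay the nitro group gives a 1.2-fold lower number from compound 3 to compound 4 (0.08 log units; within the scatter), while replacing the whole ring gives a 1.0-fold lower number from compound 2 to compound 4 (0.01 log units; within the scatter) and a 1.0-fold higher number from compound 1 to compound 4 (0.01 log units; within the scatter), so none of these steps can be told apart from repeat measurement. As far as this assay can tell, the nitro group behaves alike on the benzoate and furan esters: the same change on two cores in this assay, a 1.0-fold higher number (0.01 log units; within the scatter) from compound 1 to compound 2 and a 1.2-fold lower number (0.08 log units; within the scatter) from compound 3 to compound 4, 1.2-fold (0.09 log units) apart, within the scatter of two such steps. For the compounds shown here, this shows only that the change leaves no readable mark on either core; it does not show that a step large enough to read would carry from one core to the other.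

All four compounds shown carry an aromatic ring on the ester carbonyl. As far as these compounds go, what an amine, a carboxylic acid or a longer chain would do in that place remains open.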